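The source may report more compounds than this note shows. Statements on the series, on what has been measured and on what is new or still open speak of the compounds shown alone.

For the measured compounds named here, compound 2 `COC(=O)/C=C/c1cccc(N(Cc2ccc(/C=C/c3ccc(F)cc3)cc2)C(=O)C(C)C)c1` gives 120 nM in an assay on isolated protein with Bile acid receptor (Homo sapiens) as the target (on this read-out lower numbers stand for an effect already at smaller amounts and higher numbers for an effect only at larger amounts of compound), the higher of the two numbers measured so far. Going by the values given here, its nearest neighbour is compound 1 `COC(=O)/C=C/c1cccc(N(Cc2ccc(/C=C/c3cccc(F)c3)cc2)C(=O)C(C)C)c1`, which gives 71 nM in this assay; the only measured step, a 1.7-fold higher number from compound 1 to compound 2 (0.23 log units; within the scatter), stays within the usual scatter, so the two compounds cannot be told apart on these data.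

Compound 3 `COC(=O)/C=C/c1cccc(N(Cc2ccc(/C=C/c3scnc3C)cc2)C(=O)C(C)C)c1` has not yet been measured. Relative to compound 2 the change is 4-methyl-1,3-thiazol-5-yl in place of 4-fluorophenyl on a double-bonded chain carbon bound to a double-bonded chain carbon. Among the compounds with values here, the single measured step moves a fluorine around the same six-membered ring and leaves the ring itself in place; no measured pair exchanges that ring for a five-membered one with two hetero atoms, so the data give no direct guide to the size or direction of this change.

The expectation for compound 3 in this assay is therefore anchored on compound 2, with a wide range: 120 nM, between 35 nM and 450 nM, meaning an estimated step of no change at the digits printed from compound 2 to compound 3 (within the scatter).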

Compound 3, half-maximal effective concentration: 228 nM
Beside the measured number, compound 3's estimate is 1.9-fold (0.28 log units) below it, within the range that was stated.
By their numbers in this assay, from the lowest: compounds 1, 2 and 3 (each within the scatter of the next, the first and the last beyond it).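

In this assay, the fluorinated six-membered ring on this double-bonded chain carbon can give way to a five-membered aromatic ring with 2 hetero atoms and the compound still gives a number in the same region: the direct comparison (a 1.9-fold higher number from compound 2 to compound 3 (0.28 log units; within the scatter)) leaves the two compounds indistinguishable. The comparison with the other fluorine isomer (a 3.2-fold higher number from compound 1 to compound 3 (0.51 log units; beyond the scatter)) does go beyond the scatter, so this position shows a first modest separation, which the two fluorophenyl compounds alone did not show. Nothing available here explains that separation.

It remains open whether the methyl on the 4-methyl-1,3-thiazol-5-yl group matters, since no unmethylated 1,3-thiazol-5-yl partner appears among these compounds. Also open, as far as these compounds go, is how an unsubstituted phenyl, or a phenyl carrying an amine or a carboxylic acid, would read at this same place.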